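The compounds below may be only part of what the source reports. "The series", "measured", "known", "first", "only" and "open" are said of these compounds alone.

Measured so far in an assay for inhibition of Dihydrofolate reductase (Gallus gallus); on this read-out lower numbers stand for stronger inhibition and higher numbers for weaker inhibition:
compound 1 `Cc1ccccc1Cc1cnc(N)nc1N` gives 29500 nM
compound 2 `COCc1ccccc1Cc1cnc(N)nc1N` gives 39800 nM

Compound 2 gives the higher of the two numbers, but the step of a 1.3-fold higher number from compound 1 to compound 2 (0.13 log units; within the scatter) lies within the scatter, so compound 1 and compound 2 are not separated by this assay. Compound 3 `Nc1ncc(Cc2ccccc2O)c(N)n1` has not yet been measured; relative to compound 2 the change is hydroxy in place of methoxymethyl on an aromatic carbon. For the measured compounds named here, the only measured step, a 1.3-fold higher number from compound 1 to compound 2 (0.13 log units; within the scatter), bears on the same substituent, adding methoxy to its chain carbon, and it did not move the number beyond the scatter; no measured compound carries a hydroxy directly on the ring, so that part of the change has no precedent here. The expectation is therefore a step of a 1.3-fold lower number from compound 2 to compound 3 (0.12 log units; within the scatter), not beyond the scatter, with a wide range to either side. Compound 3 is estimated at 30000 nM in this assay, between 8000 nM and 110000 nM.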

Compound 3, inhibition constant: 89100 nM
The estimate for compound 3 lay 3.0-fold (0.47 log units) below the measured number; the range from low to high includes it.
By their numbers in this assay, from the lowest: compounds 1 and 2 (each within the scatter of the next); then compound 3.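

In this assay this aromatic carbon gives its first step beyond the scatter: hydroxy in place of methoxymethyl (a 2.2-fold higher number from compound 2 to compound 3 (0.35 log units; beyond the scatter)) and hydroxy in place of methyl (a 3.0-fold higher number from compound 1 to compound 3 (0.48 log units; beyond the scatter)) both raise the number, which makes compound 3 the weakest of the three. For the compounds shown here, compound 1 and compound 2 are not separated, so the chain carbon tolerated methoxy, while hydroxy directly on the ring is the first change here to be read as a loss, though a modest one. Nothing at hand accounts for this loss.

Open, going by these compounds, is whether the loss follows the hydrogen-bond donor that enters with hydroxy or the shorter group as a whole. An amine on the same aromatic carbon, set against a longer chain such as ethyl, would help to separate these two readings.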